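Shortening the carbamate ester in a GIP receptor series

The source may hold more compounds than are shown below. What is called first, only, known or untested is meant among the compounds shown, and "the series" means these compounds.

Compound 2 `CC(C)(C)OC(=O)N1CCC(Oc2ncnc3c2CCN3c2ccc(S(C)(=O)=O)cc2F)CC1` gives 139% in a functional assay on CHO-K1 cells with Glucose-dependent insulinotropic receptor (Homo sapiens) as the target, read by a luciferase reporter, with a stated time of 5 h (a lower number here means a smaller maximal response, a higher number a larger maximal response), the higher of the two numbers available, though compound 1 `CC(C)OC(=O)N1CCC(Oc2ncnc3c2CCN3c2ccc(C#N)cc2F)CC1` with 134% lies within the scatter of it, so no order between the two can be claimed. Compound 3 `CCOC(=O)N1CCC(Oc2ncnc3c2CCN3c2ccc(S(C)(=O)=O)cc2F)CC1` differs from compound 2 by one change: ethyl in place of tert-butyl on an oxygen next to a carbonyl group. Within the data shown here, no measured pair shows this change, so the account expects a step of a number 7 percentage points lower from compound 2 to compound 3 (within the scatter) of no size beyond the scatter, in either direction. For compound 3 the expected response is 132%, with a range from 108% to 156%.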

Compound 3, largest response reached (reported as percent of maximum), in percent of the reference or control that the assay uses: 135%
Compound 3: middle estimate off by 3 percentage points, on the low side; the measured number falls inside the stated range.
By their numbers in this assay, from the lowest: compounds 1, 3 and 2 (each within the scatter of the next).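

In this assay, ethyl in place of tert-butyl on an oxygen next to a carbonyl group gives a number 4 percentage points lower from compound 2 to compound 3 (within the scatter). Among these compounds, this is the first step read at this position, and the maximal response does not separate these two esters. No evidence bears on why the response holds across this change.

As far as these compounds go, whether a benzyl group or a longer chain on that oxygen, or an amine in place of the whole ester, would shift the response stays open. Compound 1 differs from both in more than one place, so it cannot settle this.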